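A few compounds are considered here, and "the series" means these few. Any claim that something is new, unique, unknown or untested is made for them only; others in the source may bear on it.

The shared core of compound 1 `COC(=O)CNc1c(C(=O)NCc2ccc(F)cc2)nc(Br)c2cccnc12` carries a substituted amine chain, and in a functional assay on MDA-MB-435 cells (Homo sapiens) for cytotoxicity, read by MTT assay, with a stated time of 72 h (on this read-out lower numbers stand for stronger inhibition and higher numbers for weaker inhibition), compound 1 gives 10000 nM. Compound 2 `O=C(NCCCNc1c(C(=O)NCc2ccc(F)cc2)nc(Br)c2cccnc12)c1ccccc1` differs only in that chain. In this assay compound 2 returns only a limit, > 20000 nM. Among the compounds with values here, the sole measured step, an at least 2.0-fold higher number from compound 1 to compound 2 (0.30 log units; that floor lies within the scatter), is thus a floor rather than a number, and compound 2 sits at the limit of > 20000 nM in this assay, at which 1 of the 2 values shown sits. Compound 3 `NCCCCCCNc1c(C(=O)NCc2ccc(F)cc2)nc(Br)c2cccnc12` continues from compound 2: 3-aminopropyl in place of benzamido on a saturated chain carbon, three bonds along the chain from a nitrogen on an aromatic ring. Within the data shown here, no measured step covers an exchange of benzamido for 3-aminopropyl; the only comparison in hand, an at least 2.0-fold higher number from compound 1 to compound 2 (0.30 log units; that floor lies within the scatter), shows that altering this chain carried the number beyond the reported range. Compound 3 is therefore expected to stay near the ceiling of this assay, with a fair chance of another limit. Compound 3 is estimated at 15000 nM, with a range of 6000 nM to 40000 nM. The expected step, an at least 1.3-fold lower number from compound 2 to compound 3 (0.12 log units; that floor lies within the scatter), is taken to lie within the scatter.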

Compound 3, half-maximal inhibitory concentration: 6000 nM
Estimate against measurement, compound 3: 2.5-fold (0.40 log units) above; low and high end bracket the measured number.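

In this assay, 3-aminopropyl in place of benzamido gives an at least 3.3-fold lower number from compound 2 to compound 3 (0.52 log units; beyond the scatter), so the chain end, three bonds along the chain from a nitrogen on an aromatic ring, does move the number by more than the scatter, which the earlier step could not show. The size of this step is only a floor: the limit of > 20000 nM in this assay, at which 1 of the 3 values shown sits. The other new comparison gives a 1.7-fold lower number from compound 1 to compound 3 (0.22 log units; within the scatter), so the 5-aminopentyl chain and the methoxycarbonyl chain cannot be told apart on this read-out.

Open, from the compounds shown here alone, is whether the step follows the terminal amine or the loss of the six-membered aromatic ring, as the change swaps both together. An acetamide or a carboxylic acid at the chain end, or a shorter chain ending in an amine, would separate these readings.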